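Amide Substituent Variation and an Expected Value for Compound 4

The source may hold more compounds than are shown below. What is called first, only, known or untested is meant among the compounds shown, and "the series" means these compounds.

compound 1 `COc1ccc2c(=O)c(/C=C/C(=O)Nc3cccc(Cl)c3)coc2c1`: 470 nM in a functional assay on A549 cells (Homo sapiens) for inhibition, read by MTT assay, with a stated time of 48 h; on this read-out lower numbers stand for stronger inhibition and higher numbers for weaker inhibition
compound 2 `COc1ccc2c(=O)c(/C=C/C(=O)NCc3ccccc3)coc2c1`: 11800 nM
compound 3 `COc1ccc2c(=O)c(/C=C/C(=O)Nc3cc(C)ccc3C)coc2c1`: 15500 nM

Among the three measured compounds, compound 3 has the highest number in this assay. Its nearest neighbour is compound 2, and the gap a 1.3-fold higher number from compound 2 to compound 3 (0.12 log units; within the scatter) lies within the scatter, so the two cannot be ordered. Compound 1 is far removed, as the step of a 33-fold higher number from compound 1 to compound 3 (1.52 log units; beyond the scatter) shows.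

The next compound, compound 4 `COc1ccc(CNC(=O)/C=C/c2coc3cc(OC)ccc3c2=O)cc1`, differs from compound 3 in one place: 4-methoxybenzyl in place of 2,5-dimethylphenyl on an amide-type nitrogen. Among the measured compounds shown here, two measured steps bear on this. The step of a 1.3-fold higher number from compound 2 to compound 3 (0.12 log units; within the scatter) says that a benzyl and a 2,5-dimethylphenyl on the amide nitrogen give indistinguishable numbers. The steps of a 25-fold higher number from compound 1 to compound 2 (1.40 log units; beyond the scatter) and a 33-fold higher number from compound 1 to compound 3 (1.52 log units; beyond the scatter) say that the 3-chlorophenyl of compound 1 stands apart from both. For the measured compounds named here, no measured compound carries a methoxy on the benzyl, so the data give no guidance on what that group adds. The expectation for compound 4 therefore rests on compound 2, and the estimated step of a 1.3-fold lower number from compound 3 to compound 4 (0.11 log units; within the scatter) is taken to be none beyond the scatter. Compound 4 is estimated at 12000 nM in this assay, within a range from 4000 nM to 40000 nM.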

Compound 4, half-maximal inhibitory concentration: 22500 nM
Compound 4: middle estimate off by 1.9-fold (0.27 log units), on the low side; the range from low to high includes it.
By their numbers in this assay, from the lowest: compound 1; then compounds 2, 3 and 4 (each within the scatter of the next).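

In this assay, among the compounds shown here, methoxy in place of hydrogen on an aromatic carbon of the benzyl group gives no change that can be told from the scatter (a 1.9-fold higher number from compound 2 to compound 4 (0.28 log units; within the scatter)), and this is the first reading of a substituent on that benzyl group. The 4-methoxybenzyl and 2,5-dimethylphenyl groups on the amide-type nitrogen also cannot be ordered (a 1.5-fold higher number from compound 3 to compound 4 (0.16 log units; within the scatter)), so compound 2, compound 3 and compound 4 form a single cluster on this read-out. Compound 1 remains the only one apart, and its 3-chlorophenyl now stands clear of a third substituent (a 48-fold higher number from compound 1 to compound 4 (1.68 log units; beyond the scatter)). No measured evidence is available to explain these numbers.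

On these data alone, it remains open whether the lower number of compound 1 belongs to the chloro group or to the phenyl that carries it, a question that a 3-chlorobenzyl or an unsubstituted phenyl on the amide-type nitrogen could help to settle. As far as these compounds go, it is also open whether an amine or a carboxylic acid on the benzyl group would leave the number as undisturbed as methoxy does.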